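Ether aryl change: from compound 2 to compound 4

A few compounds are considered here, and "the series" means these few. Any claim that something is new, unique, unknown or untested is made for them only; others in the source may bear on it.

Measured compounds in a functional assay on CHO-K1 cells for antagonist activity at Orexin receptor type 2 (Homo sapiens), read by FLIPR and calcium flux; on this read-out higher numbers stand for weaker inhibition and lower numbers for stronger inhibition:
compound 1 `C[C@@H]1CC[C@@H](Oc2cc(C#N)ccn2)CN1C(=O)c1ccccc1CC(F)(F)F` gives 32 nM
compound 2 `COC(=O)c1ccnc(O[C@@H]2CC[C@@H](C)N(C(=O)c3ccccc3-n3nccn3)C2)c1` gives 22 nM
compound 3 `Cc1cccc(O[C@@H]2CC[C@@H](C)N(C(=O)c3ccccc3-n3nccn3)C2)n1` gives 33 nM

The three numbers lie within the scatter of one another; compound 2 cannot be separated from compound 1 or compound 3, and the step of a 1.5-fold higher number from compound 2 to compound 3 (0.18 log units; within the scatter) confirms this. Compound 4 `C[C@@H]1CC[C@@H](Oc2cc(-c3ccccc3)ccn2)CN1C(=O)c1ccccc1-n1nccn1` differs from compound 2 by phenyl in place of methoxycarbonyl on an aromatic carbon. Among the measured compounds shown here, the only step that bears on this place is the removal of the methoxycarbonyl group from compound 2 to compound 3, which gave a 1.5-fold higher number from compound 2 to compound 3 (0.18 log units; within the scatter); the group is therefore not needed for inhibition. Nothing measured tells how a phenyl at this carbon behaves. The step of a 1.3-fold higher number from compound 2 to compound 4 (0.10 log units; within the scatter) is expected to stay within the scatter. Compound 4 is estimated at 28 nM, range 8 nM to 100 nM.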

Compound 4, half-maximal inhibitory concentration: 45 nM
Estimate against measurement, compound 4: 1.6-fold (0.21 log units) below, within the range that was stated.
By their numbers in this assay, from the lowest: compounds 2, 1, 3 and 4 (each within the scatter of the next, the first and the last beyond it).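

At this carbon, opposite the ring nitrogen, the shared core tolerates a phenyl in this assay, but a 2.0-fold higher number from compound 2 to compound 4 (0.31 log units; beyond the scatter) is a modest loss of inhibition. Among the compounds shown here, the exchange of methoxycarbonyl for a six-membered aromatic ring of carbon only therefore has a small but readable cost, which the earlier compounds did not reveal. Nothing available accounts for this step.

On these data alone, it remains open whether a cyclohexyl ring, a carboxylic acid or an amine at this carbon would stay close to compound 2. As far as these compounds go, it is also open whether a substituent on the phenyl would recover the lost inhibition.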